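The compounds below may be only part of what the source reports. "The series", "measured", "known", "first", "only" and "open" are said of these compounds alone.

Three members of the series have been read in a functional assay on Vero cells (Chlorocebus sabaeus) for inhibition; on this read-out lower numbers stand for stronger inhibition and higher numbers for weaker inhibition. Compound 1 `Nc1nc(=O)n([C@@H]2CS[C@@H](CO)O2)cc1Br`, the bromo member, returns only a limit of the assay, > 100000 nM. Compound 2 `Cc1cn([C@H]2CS[C@@H](CO)O2)c(=O)nc1N`, a methyl member, also returns only a limit, > 100000 nM. For the measured compounds named here, compound 3 `Nc1nc(=O)n([C@@H]2CS[C@@H](CO)O2)cc1Cl`, the chloro member, gives 31200 nM, the only true number so far. The rest of the picture is the limit of > 100000 nM in this assay, at which 2 of the 3 values shown sit.

Compound 4 `Cc1cn([C@@H]2CS[C@@H](CO)O2)c(=O)nc1N` follows from compound 3 with methyl in place of chloro on an aromatic carbon. Going by the values given here, no measured step covers this exchange directly. The closest is an at least 3.2-fold lower number from compound 1 to compound 3 (0.50 log units; beyond the scatter), with chloro in place of bromo on an aromatic carbon, so the read-out does respond to the group at this place. Among the compounds with values here, compound 4 shares the methyl group with compound 2, whose value > 100000 nM is a limit, but the two are different structures and no measured step links them.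

A move to a higher number in this assay, of roughly the size of the halogen step, is therefore expected. The expected change is a 2.6-fold higher number from compound 3 to compound 4 (0.41 log units; beyond the scatter). The estimate for compound 4 is 80000 nM, with an expected range of 25000 nM to 200000 nM, and a report as a limit alone would not surprise.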

Compound 4, half-maximal inhibitory concentration: > 100000 nM
Compound 4: a limit, no number; the forecaster's own chance of this, stated with the estimate: 60%; middle value at least 1.2-fold (0.09 log units) away from the limit.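

Methyl in place of chloro on the aromatic carbon gives an at least 3.2-fold higher number from compound 3 to compound 4 (0.50 log units; beyond the scatter) in this assay, so this position responds to a second exchange and not only to the swap between halogens, where the earlier step was an at least 3.2-fold lower number from compound 1 to compound 3 (0.50 log units; beyond the scatter). For the compounds shown here, compound 3 therefore stands apart from both the bromo and the methyl member at this place, and chloro remains the only group here with a true number, while the other values are limits: the limit of > 100000 nM in this assay, at which 3 of the 4 values shown sit. The steps joining compound 4 to compound 1 and to compound 2 cannot be read, as both ends of each are limits, so this pair gives no reading of the stereocentre: the fact that compounds 2 and 4 differ only in the configuration as drawn.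

As far as these compounds go, the full size of the steps out of compound 3 stays open, since only limits stand on the other side of them. Also open, from the compounds shown here alone, are how a fluoro, an ethyl or an amino group on this aromatic carbon would read, and how the chloro member would read with the stereocentre drawn as in compound 2.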